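Swapping one chloro for hydrogen on compound 2

This account rests on a few compounds, and the source may have more. Where it says the series, first, only, none or still open, it means among the compounds named here.

In a functional assay on the whole organism with Mus musculus as the target (on this read-out lower numbers stand for an effect already at smaller amounts and higher numbers for an effect only at larger amounts of compound), compound 2 `Cn1nc(-c2ccc(Cl)cc2Cl)n(C)c1=S` gives > 25 mg/kg, which is a limit of the assay and not a number.

In this assay compound 3 `Cn1nc(-c2ccc(Cl)cc2)n(C)c1=S` gives 1.34 mg/kg, and compound 1 `CCn1c(-c2ccccc2)nn(C)c1=S` gives 0.58 mg/kg.

Compound 4 `Cn1nc(-c2ccccc2Cl)n(C)c1=S` is still unmeasured. It differs from compound 2 by hydrogen in place of chloro on an aromatic carbon, a hydrogen in place of chloro, meta to a chloro group.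

Going by the values given here, the one measured step that bears on this is an at least 18-fold lower number from compound 2 to compound 3 (1.27 log units; beyond the scatter), which also replaces a chloro with hydrogen, though the other one. Compound 4 keeps the chloro that compound 3 lacks, so a lower number is expected in this assay, but probably a smaller step.

The estimated change is an at least 3.1-fold lower number from compound 2 to compound 4 (0.49 log units; beyond the scatter).

Compound 4 is expected at 8 mg/kg, within 1.5 mg/kg to 25 mg/kg.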

Compound 4, dose for half-maximal effect: 0.37 mg/kg
For compound 4 the middle estimate is 22-fold (1.33 log units) above the measured one, outside the stated range (below it).
By their numbers in this assay, from the lowest: compounds 4 and 1 (each within the scatter of the next); then compound 3. At a limit, above all of these: compound 2.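

Going by these compounds alone, replacing this chloro, the one para to a group of 8 heavy atoms, with hydrogen gives an at least 67-fold lower number from compound 2 to compound 4 (1.82 log units; beyond the scatter) in this assay. Replacing the other chloro gives an at least 18-fold lower number from compound 2 to compound 3 (1.27 log units; beyond the scatter), so a large step follows whichever of the two chloro groups leaves. From the compounds shown here alone, compound 2 gives > 25 mg/kg, which is a limit of the assay and not a number, so the full size of both steps stays unknown.

Only chloro and hydrogen appear at this position in the compounds shown. Going by these compounds, what a methoxy group, an amine or a longer chain would do there remains open.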